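Notes on the step from compound 3 to compound 4

The compounds below may be only part of what the source reports. "The series", "measured", "known", "first", "only" and "open" are said of these compounds alone.

Values in an ADME assay on microsomes from liver (Mus musculus) for metabolic stability, with a stated time of 10 min, tested at 0.5 uM; a lower number here means that less of the compound is left, a higher number that more of the compound is left:
- Compound 1 `C[C@@H](C(=O)NC1CCCCC1)[C@H]1CC[C@@H](c2ccnc3ccc(F)cc32)CC1`: < 1% (a limit of the assay)
- Compound 2 `C[C@@H](CNc1ccc(Cl)cc1)[C@H]1CC[C@@H](c2ccnc3ccc(F)cc32)CC1`: 80%
- Compound 3 `C[C@@H](NCc1ccc(Cl)cc1)[C@H]1CC[C@@H](c2ccnc3ccc(F)cc32)CC1`: 2%

Compound 3 has the lower of the two actual numbers, 2%. For the measured compounds named here, the only other actual number is much higher, with a number 78 percentage points lower from compound 2 to compound 3 (beyond the scatter). Against the limit, the step is a number at least 1 percentage points higher from compound 1 to compound 3 (that floor lies within the scatter).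

Compound 4 `C[C@@H](NS(=O)(=O)c1ccc(Cl)cc1)[C@H]1CC[C@@H](c2ccnc3ccc(F)cc32)CC1` carries (4-chlorophenyl)sulfonyl in place of 4-chlorobenzyl on an amine nitrogen. Going by the values given here, no measured step involves this group. The nearest guides are changes at the same carbon: a number at least 79 percentage points higher from compound 1 to compound 2 (beyond the scatter), and the reverse-direction contrast a number 78 percentage points lower from compound 2 to compound 3 (beyond the scatter). Among the compounds with values here, these show that the series responds strongly to changes here, although only one compound reaches a high value. That compound is compound 2 at 80%, which carries a (4-chlorophenyl)amino group. An upward step of moderate to large size is therefore expected in this assay, with wide uncertainty, and a result close to compound 3 remains possible.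

For compound 4 the estimated value is 40%, with an expected range of 5% to 85%. The expected change is a number 38 percentage points higher from compound 3 to compound 4 (beyond the scatter).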

Compound 4, percent of the compound remaining: < 1%
Compound 4: a limit, no number; the forecaster's own chance of this, stated with the estimate: 5%; middle value at least 39 percentage points from the limit.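

In this assay compound 4 gives < 1%, which is a limit of the assay and not a number. Exchanging 4-chlorobenzyl for (4-chlorophenyl)sulfonyl on the amine nitrogen gives a number at least 1 percentage points lower from compound 3 to compound 4 (that floor lies within the scatter), so a second, quite different substituent on this nitrogen also leaves the read-out at the low end, and the added hydrogen-bond acceptors of the sulfonyl group bring no visible gain. Among the compounds shown, a low read-out now holds for compound 1, compound 3 and compound 4, with compound 2 at 80% as the one that goes against it. The gap from compound 3 to compound 4 cannot be sized because both values lie at the low end, one of them on the floor of the assay: the limit of < 1% in this assay, at which 2 of the 4 values shown sit.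

The compounds shown leave open which feature of compound 2 carries its high value, the (4-chlorophenyl)amino group itself or the methyl carbon that links it to the chain. A tertiary amine, a carboxylic acid or a longer chain carrying the 4-chlorophenyl ring at this carbon would be needed to settle how narrow that requirement is.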